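Methoxycarbonyl to carboxy, with only limits so far

A few compounds are considered here, and "the series" means these few. Any claim that something is new, unique, unknown or untested is made for them only; others in the source may bear on it.

In an ADME assay on CEMx174 cells (Homo sapiens) for cytotoxicity (a lower number here means that less compound is tolerated, a higher number that more compound is tolerated), compound 1 (`CCC1=C(C(=O)OCC2CCCCC2)C(c2ccc([N+](=O)[O-])cc2)NC(=O)N1`) gives > 10000 nM as a limit of the assay. Compound 2 (`CCC1=C(C(=O)OCC2CCCCC2)C(c2ccc(C(=O)OC)cc2)NC(=O)N1`) gives > 10000 nM as a limit too. Going by the values given here, the only measured step is a step that the two limits leave unreadable from compound 1 to compound 2 and offers no size to carry forward. The evidence amounts to the limit of > 10000 nM in this assay, at which 2 of the 2 values shown sit, and no more. Compound 3 (`CCC1=C(C(=O)OCC2CCCCC2)C(c2ccc(C(=O)O)cc2)NC(=O)N1`) differs from compound 2 by hydrogen in place of methyl on an oxygen next to a carbonyl group, methoxycarbonyl to carboxy (hydrogen in place of methyl on an oxygen next to a carbonyl group). With no readable step to go on, no change beyond the scatter is expected in this assay in either direction. The expected change is a step that the limit leaves unreadable from compound 2 to compound 3 and remains an estimate. Compound 3 is estimated at 20000 nM within an expected range of 10000 nM to 60000 nM. A limit of the assay is the likely outcome for compound 3 as well.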

Compound 3, half-maximal cytotoxic concentration: > 10000 nM
Compound 3: a limit, no number (the forecaster's own chance of this, stated with the estimate: 85%); the middle value does not contradict the limit.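

No step can be read among compound 1, compound 2 and compound 3, as all three sit at a limit in this assay. The compounds shown leave open whether nitro, methoxycarbonyl and carboxy on an aromatic carbon differ at all in the concentration tolerated.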